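Bromo for Methyl at the Far End of the Ester

The source may hold more compounds than are shown below. What is called first, only, known or untested is meant among the compounds shown, and "the series" means these compounds.

Compound 1 `COc1cc(C2Oc3cc([C@H]4Oc5cc(O)cc(O)c5C(=O)[C@@H]4O)ccc3OC2COC(=O)c2ccc([N+](=O)[O-])cc2)ccc1O`: in a functional assay, read by spectrophotometry, with a stated time of 30 min (on this read-out lower numbers stand for an effect already at smaller amounts and higher numbers for an effect only at larger amounts of compound), compound 1 reaches only the assay limit, > 300000 nM.
Compound 2 `COc1cc(C2Oc3cc([C@H]4Oc5cc(O)cc(O)c5C(=O)[C@@H]4O)ccc3OC2COC(=O)c2cc([N+](=O)[O-])cc([N+](=O)[O-])c2)ccc1O`: compound 2 gives 205000 nM.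
Compound 3 `COc1cc(C2Oc3cc([C@H]4Oc5cc(O)cc(O)c5C(=O)[C@@H]4O)ccc3OC2COC(=O)/C=C/c2ccc(C)cc2)ccc1O`: compound 3 gives 136000 nM.

Compound 3 has the lowest of the two plain numbers; the step of a 1.5-fold lower number from compound 2 to compound 3 (0.18 log units; within the scatter) stays within the scatter, while an at least 2.2-fold lower number from compound 1 to compound 3 (0.34 log units; beyond the scatter) is at least modest and an at least 1.4-fold lower number from compound 1 to compound 2 (0.16 log units; that floor lies within the scatter) is uncertain because of the limit of > 300000 nM in this assay, at which 1 of the 3 values shown sits. Compound 4 `COc1cc(C2Oc3cc([C@H]4Oc5cc(O)cc(O)c5C(=O)[C@@H]4O)ccc3OC2COC(=O)/C=C/c2ccc(Br)cc2)ccc1O` differs from compound 3 only by bromo in place of methyl on an aromatic carbon. For the measured compounds named here, none of the measured steps touches that aromatic ring; each swaps the whole group on the carbonyl carbon. So no step beyond the scatter is expected, a 1.1-fold lower number from compound 3 to compound 4 (0.05 log units; within the scatter). Compound 4 is therefore estimated at 120000 nM, between 50000 nM and 300000 nM.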

Compound 4, half-maximal effective concentration: 88900 nM
The estimate for compound 4 lay 1.3-fold (0.13 log units) above the measured number; the range from low to high includes it.
By their numbers in this assay, from the lowest: compounds 4, 3 and 2 (each within the scatter of the next, the first and the last beyond it). At a limit, above all of these: compound 1.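

For the compounds shown here, at this position, on an aromatic carbon, bromo for methyl is the only change that leaves the rest of the ester untouched, and it gives a 1.5-fold lower number from compound 3 to compound 4 (0.18 log units; within the scatter). Yet only the bromo compound clears the scatter against the dinitro ester, with a 2.3-fold lower number from compound 2 to compound 4 (0.36 log units; beyond the scatter), whereas compound 3 did not. Against the nitro ester the step is an at least 3.3-fold lower number from compound 1 to compound 4 (0.52 log units; beyond the scatter), which is only a floor since compound 1 is held at a limit: the limit of > 300000 nM in this assay, at which 1 of the 4 values shown sits.

From the compounds shown here alone, whether a methoxy group, an amine or a carboxylic acid on this ring carbon would shift the number remains open. So does whether a plain hydrogen there would serve equally well.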